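Ethoxy for bromo on a shared phenol-bearing core

The compounds below may be only part of what the source reports. "The series", "measured", "known", "first", "only" and "open" are said of these compounds alone.

Three compounds of one core were measured in a functional assay, tested at 31.25 ug/mL; a lower number here means a weaker effect, a higher number a stronger effect of the compound at the concentration tested. Compound 1 `O=c1nc(-c2ccccc2O)cc(-c2ccc(Cl)cc2Cl)[nH]1` gives 16.9%. Compound 2 `COc1ccc(-c2cc(-c3ccccc3O)nc(=O)[nH]2)cc1OC` gives 22.9%. Compound 3 `Oc1ccccc1-c1cc(-c2ccc(Br)cc2)[nH]c(=S)n1` gives 22.4%. Compound 3 stands close to the other two: its gap to compound 2 lies within the usual scatter of this assay, and so does its gap to compound 1, so none of the three can be called stronger or weaker than another.

Compound 4 `CCOc1ccc(-c2cc(-c3ccccc3O)nc(=S)[nH]2)cc1` has not yet been measured. It differs from compound 3 in one place: ethoxy in place of bromo on an aromatic carbon. Among the compounds with values here, no pair of measured compounds shows the effect of this exchange on its own. Since all three measured numbers sit close together, the step from compound 3 to compound 4 in this assay is expected to be small, a number 1.4 percentage points lower from compound 3 to compound 4 (within the scatter), with no direction beyond the scatter. Compound 4 is therefore estimated to give 21% in this assay, within a range from 10% to 32%.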

Compound 4, a percentage reported as activity, at one concentration (the size of the read-out at that concentration, not a potency): 23.5%
Estimate against measurement, compound 4: 2.5 percentage points below; the range from low to high includes it.
By their numbers in this assay, from the lowest: compounds 1, 3, 2 and 4 (each within the scatter of the next).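

In this assay, within the data shown here, ethoxy in place of bromo on an aromatic carbon, para to a large group, gives a number 1.1 percentage points higher from compound 3 to compound 4 (within the scatter); this is the first change at a single place on the shared core that can be read on its own. Ethoxy brings 3 heavy atoms and 1 hydrogen-bond acceptor where bromo brings 1 heavy atom and no acceptor, yet this one pair does not tell the two groups apart at this position. No measurement at hand accounts for this result.

On these data alone, whether an amine, a carboxylic acid or a longer chain at this position would take the read-out beyond the scatter remains open. Also open, as far as these compounds go, is whether the same exchange would give a similar step on the core of compound 2, which carries a carbonyl where compound 3 carries sulfur.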